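The compounds below may be only part of what the source reports. "The series", "measured", "known", "first", "only" and "open" are said of these compounds alone.

Of the compounds shown here, three of a shared core have been measured in an assay on isolated protein for binding affinity to Type-2 angiotensin II receptor (Homo sapiens); on this read-out lower numbers stand for stronger inhibition and higher numbers for weaker inhibition. Compound 1 `CCCc1nc(CC)c(C(=O)OCC(=O)c2ccccc2)n1Cc1ccc(-c2ccccc2S(=O)(=O)NC(=O)OCCC(C)C)cc1F` gives 2 nM. Compound 2 `CCCOC(=O)NS(=O)(=O)c1ccccc1-c1ccc(Cn2c(CCC)nc(CC)c2C(=O)OCc2cccc(C(=O)c3ccccc3)c2)c(F)c1` gives 10 nM, and compound 3 `CCCc1nc(CC)c(C(=O)OCc2cccc(C(=O)c3ccccc3)c2)n1Cc1ccc(-c2ccccc2S(=O)(=O)NC(=O)OCCC(C)C)cc1F` gives 0.9 nM. Compound 1 thus sits second highest of the three numbers, with compound 3 the nearest and compound 2 the furthest away.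

Compound 4 `CCCc1nc(CC)c(C(=O)OCc2ccccc2OCCC(C)C)n1Cc1ccc(-c2ccccc2S(=O)(=O)NC(=O)OCCC(C)C)cc1F` is not yet measured. It differs from compound 1 in one place: 2-(isopentyloxy)phenyl in place of benzoyl on a saturated chain carbon bound to an oxygen next to a carbonyl group.

Within the data shown here, only one measured step is known in one place, an 11-fold lower number from compound 2 to compound 3 (1.05 log units; beyond the scatter), and it touches the carbamate chain, not the ester group changed here. Compound 1 and compound 3 do differ at the ester group, and their values lie close together, which suggests that the ester group tolerates some variation. Among the measured compounds shown here, since no step directly covers the new group, the expectation for compound 4 in this assay is a number near that of compound 1, a step of a 1.3-fold higher number from compound 1 to compound 4 (0.10 log units; within the scatter), with a value estimated at 2.5 nM and a range from 0.7 nM to 9 nM.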

Compound 4, half-maximal inhibitory concentration: 10 nM
Compound 4: middle estimate off by 4.0-fold (0.60 log units), on the low side; measured number above the stated range.
By their numbers in this assay, from the lowest: compound 3; then compound 1; then compounds 2 and 4 (each within the scatter of the next).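

In this assay, among these compounds, the ester group proves less forgiving than the earlier compounds suggested: 2-(isopentyloxy)phenyl in place of benzoyl, on the saturated chain carbon bound to an oxygen next to a carbonyl group, gives a 5.0-fold higher number from compound 1 to compound 4 (0.70 log units; beyond the scatter). The group carried at this place therefore does change the read-out, and the entering group, with 12 heavy atoms against 8 for benzoyl, is not simply accepted as an equal. No measurement at hand speaks to why the number rises.

The compounds shown leave open whether the isopentyloxy chain or the swap away from benzoyl accounts for the step. A methoxy group in place of that chain, or an amine at its end, would help separate the two.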